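This account rests on a few compounds, and the source may have more. Where it says the series, first, only, none or still open, it means among the compounds named here.

The measured compounds:

Compound 1, `Cc1cccc(CSc2cc(Cl)c(C)cc2S(=O)(=O)/N=C(\N)n2nccc2-c2ccccc2)c1`, gives 0.232 h in an ADME assay on microsomes from liver (Homo sapiens) for metabolic stability, read by LC-MS, using NADPH, tested at 5 uM; on this read-out higher numbers stand for a longer-lived compound and lower numbers for a shorter-lived compound.
Compound 2, `Cc1cc(-c2ccccc2)n(/C(N)=N/S(=O)(=O)c2cc(C)c(Cl)cc2SCc2cccc3ccccc23)n1`, gives 0.256 h in this assay.
Compound 3, `Cc1cc(-c2ccccc2)n(/C(N)=N/S(=O)(=O)c2cc(C)c(Cl)cc2SCc2cccc(Cl)c2)n1`, gives 0.205 h in this assay.

All three share one core and differ only in the group carried on a saturated chain carbon bound to a sulfur. Compound 1 stands second highest of the three numbers; its nearest neighbour is compound 2 and its furthest is compound 3, and both of those gaps lie within the scatter of repeated measurements. For the measured compounds named here, the one step between two measured compounds that differ in a single place is a 1.2-fold lower number from compound 2 to compound 3 (0.10 log units; within the scatter), so exchanging naphthalen-1-yl for 3-chlorophenyl at that place left the half-life essentially where it was.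

Compound 4, `Cc1ccc(CSc2cc(Cl)c(C)cc2S(=O)(=O)/N=C(\N)n2nccc2-c2ccccc2)cc1`, differs from compound 1 by 4-methylphenyl in place of 3-methylphenyl on a saturated chain carbon bound to a sulfur. The change sits at the same place as the measured step, and that step did not move the number beyond the scatter, while the three measured values themselves lie within the scatter of one another. Compound 4 is therefore expected to show no step beyond the scatter in this assay, and the expected step is a 1.0-fold lower number from compound 1 to compound 4 (0.00 log units; within the scatter). Compound 4 is estimated at 0.23 h, with a range from 0.12 h to 0.46 h.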

Compound 4, half-life: 0.13 h
Compound 4: middle estimate off by 1.8-fold (0.25 log units), on the high side; low and high end bracket the measured number.
By their numbers in this assay, from the lowest: compounds 4, 3, 1 and 2 (each within the scatter of the next).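

In this assay, exchanging 3-methylphenyl for 4-methylphenyl on a saturated chain carbon bound to a sulfur gives a 1.8-fold lower number from compound 1 to compound 4 (0.25 log units; within the scatter). The two groups hold the same atoms joined differently, so this step tests the place of the methyl alone, which the earlier step between naphthalen-1-yl and 3-chlorophenyl could not do. Like that earlier step, it stays within the scatter, so these compounds do not show that moving the methyl matters for the half-life, although four compounds cannot exclude a small effect. Nothing measured here bears on why the number of compound 4 falls where it does.

The compounds shown leave open whether any group at this place can carry the half-life beyond the scatter, as all the groups here are hydrocarbon or chlorinated aromatic groups. An amine or a carboxylic acid on the aromatic ring, or a longer chain in place of the single saturated carbon bound to the sulfur, could answer that in this assay.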